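The source may report more compounds than this note shows. Statements on the series, on what has been measured and on what is new or still open speak of the compounds shown alone.

The measured compounds:
Compound 1 `CC(C)CSc1nc(N)nc2c1ncn2/C=C1/CC1(CO)CO`: in an ADME assay on BCBL1 cells (Homo sapiens) for cytotoxicity, with a stated time of 7 days (a higher number here means that more compound is tolerated, a lower number that less compound is tolerated), compound 1 gives > 20000 nM, a limit of the assay.
Compound 2 `Nc1nc(OCc2ccccc2)c2ncn(/C=C3/CC3(CO)CO)c2n1`: in this assay compound 2 gives > 20000 nM, likewise a limit.
Compound 3 `CCCCCCCCSc1nc(N)nc2c1ncn2/C=C1/CC1(CO)CO`: in this assay compound 3 gives > 20000 nM, likewise a limit.

Compound 2 thus stands at the limit of > 20000 nM in this assay, at which 3 of the 3 values shown sit, where every value in this set sits. Compound 4 `CCCOc1nc(N)nc2c1ncn2/C=C1/CC1(CO)CO` differs from compound 2 by ethyl in place of phenyl on a saturated chain carbon bound to an oxygen on an aromatic ring. The steps among the measured compounds are a step that the two limits leave unreadable from compound 1 to compound 2, a step that the two limits leave unreadable from compound 1 to compound 3 and a step that the two limits leave unreadable from compound 2 to compound 3; none of them gives a readable size, so they offer no guide to the direction or size of the change from compound 2 to compound 4. With all three values sitting at the limit, compound 4 is expected to be tolerated to a comparable degree, so the step that the limit leaves unreadable from compound 2 to compound 4 is estimated to be small. Compound 4 is therefore estimated at 30000 nM, within 15000 nM to 60000 nM, and is most likely to be reported again only as a limit.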

Compound 4, half-maximal cytotoxic concentration: > 20000 nM
Compound 4: only a limit was reported (the forecaster's own chance of this, stated with the estimate: 85%); the middle value lies beyond the limit too.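

In this assay compound 4 gives > 20000 nM, a limit, so its steps from compound 1, compound 2 and compound 3 cannot be read. The compounds shown leave open at what concentration any of them becomes cytotoxic.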